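Swapping the Amine-Bearing Ring for a Bromophenol

The source may hold more compounds than are shown below. What is called first, only, known or untested is meant among the compounds shown, and "the series" means these compounds.

Compound 1, `COc1ccc(C(=O)/C=C/c2ccc(N(C)C)cc2)c2c1C=CC(C)(C)O2`, holds the lower of the two measured numbers shown here. In a functional assay on SW-620 cells (Homo sapiens) for antiproliferative activity, read by MTT assay, with a stated time of 24 h (on this read-out lower numbers stand for stronger inhibition and higher numbers for weaker inhibition), compound 1 gives 570 nM. Compound 2, `COc1ccc(C(=O)/C=C/c2ccc3ccccc3c2)c2c1C=CC(C)(C)O2`, gives 2140 nM in this assay, a weaker result that lies beyond the usual scatter. Compound 3, `COc1ccc(C(=O)/C=C/c2ccc(N(c3ccccc3)c3ccccc3)cc2)c2c1C=CC(C)(C)O2`, gives only > 10000 nM in this assay; this is a limit of the assay, not a number. Compound 4, `COc1ccc(C(=O)/C=C/c2ccc(O)c(Br)c2)c2c1C=CC(C)(C)O2`, has not yet been measured. It differs from compound 1 in one place: 3-bromo-4-hydroxyphenyl in place of 4-(dimethylamino)phenyl on a double-bonded chain carbon bound to a double-bonded chain carbon. Among the compounds with values here, no measured pair shows a change of this kind, so the size of the step is uncertain; a moderate loss of activity is expected, described by a 2.6-fold higher number from compound 1 to compound 4 (0.42 log units; beyond the scatter). In this assay compound 4 is estimated at 1500 nM, with a likely range from 500 nM to 5000 nM.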

Compound 4, half-maximal inhibitory concentration: > 10000 nM
Compound 4 was reported as a limit; the forecaster's own chance of this, stated with the estimate: 10%; middle value at least 6.6-fold (0.82 log units) away from the limit.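

Putting 3-bromo-4-hydroxyphenyl in place of 4-(dimethylamino)phenyl gives an at least 17-fold higher number from compound 1 to compound 4 (1.24 log units; beyond the scatter), the only single-place change shown here, and it is large. Keeping a six-membered aromatic ring at this place is therefore not enough to retain the activity of compound 1 in this assay. The full size of the step cannot be read, as the result for compound 4 is a limit and not a number: the limit of > 10000 nM in this assay, at which 2 of the 4 values shown sit.

From the compounds shown here alone, it remains open whether the hydroxyl, the bromine or the loss of the dimethylamino group accounts for the drop. A ring carrying only the hydroxyl, only the bromine, or a primary amine would help separate these.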